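A few compounds are considered here, and "the series" means these few. Any claim that something is new, unique, unknown or untested is made for them only; others in the source may bear on it.

Compound 1 `COCCNC(=O)c1cnn(-c2cccc3cc(Cc4cccc(C(F)(F)F)c4)sc23)c1` gives 62 nM in a functional assay on CHO cells for agonist activity at G-protein coupled receptor 52 (Homo sapiens), read by AlphaScreen and cAMP accumulation, with a stated time of 30 min (on this read-out higher numbers stand for an effect only at larger amounts of compound and lower numbers for an effect already at smaller amounts), and compound 2 `O=C(NCCO)c1cnn(-c2cccc3cc(Cc4cccc(C(F)(F)F)c4)sc23)c1` gives 87 nM in this assay, a change of a 1.4-fold higher number from compound 1 to compound 2 (0.15 log units; within the scatter). Compound 3 `Cc1nn(-c2cccc3cc(Cc4cccc(C(F)(F)F)c4)sc23)cc1C(=O)NCCO` gives 5.2 nM in this assay, and the step of a 17-fold lower number from compound 2 to compound 3 (1.22 log units; beyond the scatter) is large. Compound 3 thus stands lowest of the three numbers, with compound 1 nearest and compound 2 furthest, both beyond the scatter.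

Compound 4 `Cc1nn(-c2cccc3cc(Cc4cccc(C(F)(F)F)c4)sc23)c(C)c1C(=O)NCCO` differs from compound 3 by methyl in place of hydrogen on an aromatic carbon. Within the data shown here, the one measured step that bears on this is a 17-fold lower number from compound 2 to compound 3 (1.22 log units; beyond the scatter), where a methyl also entered an aromatic carbon of this ring, though on another carbon. Among the measured compounds shown here, no step shows a second methyl on the ring, so the expected step of a 1.5-fold higher number from compound 3 to compound 4 (0.19 log units; within the scatter) in this assay is modest, in either direction. Compound 4 is therefore estimated at 8 nM, within 2 nM to 30 nM.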

Compound 4, half-maximal effective concentration: 15 nM
Compound 4: the middle estimate sits 1.9-fold (0.27 log units) below what was measured, within the range that was stated.
By their numbers in this assay, from the lowest: compound 3; then compound 4; then compounds 1 and 2 (each within the scatter of the next).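

In this assay, a methyl on the aromatic carbon next to the ring atom that bears the (2-hydroxyethyl)carbamoyl group gives a 2.9-fold higher number from compound 3 to compound 4 (0.46 log units; beyond the scatter) and so moves the number up. The same kind of change elsewhere on this ring gave a 17-fold lower number from compound 2 to compound 3 (1.22 log units; beyond the scatter) in the opposite direction, so the effect of a methyl on this ring depends on the carbon that carries it. Nothing measured here explains that difference. The compounds shown leave open how an ethyl group, a chlorine atom or an amine would compare with methyl at this carbon. They also leave open whether this step would hold with the 2-methoxyethyl amide of compound 1.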